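Trading a tert-Butylamino Group for Piperidinyl

The compounds below may be only part of what the source reports. "The series", "measured", "known", "first", "only" and "open" are said of these compounds alone.

Compound 1 `CC(C)(C)NCC(=O)Nc1nc2ccc(Cl)cc2s1` was tested in a functional assay on the whole organism with Mus musculus as the target, with a stated time of 0.5 h (on this read-out lower numbers stand for an effect already at smaller amounts and higher numbers for an effect only at larger amounts of compound), and gives 100 mg/kg. Compound 2 `O=[N+]([O-])c1ccc(/C=N/NC(=S)Nc2nc3ccc(Cl)cc3s2)cc1` in this assay gives 300 mg/kg. Of these two numbers compound 1 has the lower one, and compound 2 lies beyond the scatter above it; since the two compounds differ in more than one place, their gap cannot be traced to any single change.

Compound 3 `O=C(CN1CCCCC1)Nc1nc2ccc(Cl)cc2s1` has not yet been measured in this assay. It differs from compound 1 in one place: piperidin-1-yl in place of (tert-butyl)amino on a saturated chain carbon bound to a carbonyl carbon. The carbonyl and the shared core are kept, and only the group on the saturated chain carbon bound to the carbonyl carbon is exchanged.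

No pair of measured compounds isolates a change of this kind, so there is no shown step to lean on. Because compound 1 gives 100 mg/kg and the rest of the molecule is unchanged, the step of no change at the digits printed from compound 1 to compound 3 (within the scatter) is expected to stay within the scatter, with no direction favoured. Compound 3 is therefore estimated at 100 mg/kg, with a range from 50 mg/kg to 300 mg/kg.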

Compound 3, minimum effective dose: 100 mg/kg
For compound 3 middle estimate and measured number coincide at the digits printed; low and high end bracket the measured number.
By their numbers in this assay, from the lowest: compounds 1 and 3 (each within the scatter of the next); then compound 2.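

In this assay, among the compounds shown here, the step of no change at the digits printed from compound 1 to compound 3 (within the scatter) is the first that isolates a single change at this position, since compounds 1 and 2 differ in more than one place. It shows that, for this pair, the read-out does not separate an open (tert-butyl)amino group, which carries a hydrogen-bond donor, from piperidin-1-yl, a six-membered non-aromatic ring with none, on a saturated chain carbon bound to a carbonyl carbon. The result describes this one exchange on the shared core, and no further measurement is available to explain it.

The compounds shown leave open whether a nitrogen on this chain carbon is needed at all, as neither of the two groups compared here lacks one, and a methoxy group or a plain cyclohexyl ring in the same place would address that question. They also leave open how far the position tolerates other changes, such as a morpholine ring with its added oxygen, a carboxylic acid, or a longer chain between the carbonyl and the amine.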